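The source may report more compounds than this note shows. Statements on the series, on what has been measured and on what is new or still open speak of the compounds shown alone.

Measured so far in a functional assay (Cavia porcellus) with sulfonylurea receptors; K-ATP channels (Homo sapiens) as the target; on this read-out lower numbers stand for stronger inhibition and higher numbers for weaker inhibition:
compound 1, `CC(O)(C(=O)Nc1cccc(S(=O)(=O)c2ccccc2)c1)C(F)(F)F`: > 30000 nM
compound 2, `CC(O)(C(=O)Nc1ccc(S(=O)(=O)c2ccc(F)cc2)cc1)C(F)(F)F`: 8600 nM
compound 3, `CC(O)(C(=O)Nc1ccc(S(=O)(=O)c2ccccc2)c(O)c1)C(F)(F)F`: 430 nM

Of the compounds shown here, three sharing the same core have been tested in this assay. For compound 1 only a limit is recorded, (the limit of > 30000 nM in this assay, at which 1 of the 3 values shown sits), so no number is known for it. Of the two numbers that are known, compound 2 gives 8600 nM and compound 3 gives 430 nM; compound 2 therefore stands at the higher of the two, the weaker inhibitor of the pair.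

Compound 4, `CC(O)(C(=O)Nc1ccc(S(=O)(=O)c2ccccc2O)cc1)C(F)(F)F`, has not yet been measured in this assay. It differs from compound 2 in one place: 2-hydroxyphenyl in place of 4-fluorophenyl on a sulfonyl sulfur. Within the data shown here, no step between measured compounds matches this change, so its size can only be guessed. Compound 3, which also carries a hydroxy group, gives 430 nM, a lower number than compound 2, but that hydroxy group sits on the other ring.

Compound 4 is expected to give a somewhat lower number than compound 2, a step of a 2.2-fold lower number from compound 2 to compound 4 (0.33 log units; beyond the scatter). The estimate for compound 4 is 4000 nM, within a range from 1000 nM to 20000 nM.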

Compound 4, half-maximal inhibitory concentration: 3090 nM
Compound 4: middle estimate off by 1.3-fold (0.11 log units), on the high side; the measured number falls inside the stated range.
By their numbers in this assay, from the lowest: compound 3; then compound 4; then compound 2. At a limit, above all of these: compound 1.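

In this assay, the group on a sulfonyl sulfur proves open to exchange, with a modest change in inhibition: a 2.8-fold lower number from compound 2 to compound 4 (0.44 log units; beyond the scatter). Among these compounds, this is the first comparison of compounds differing in one place, and it shows that 2-hydroxyphenyl is tolerated there in place of 4-fluorophenyl, with the number moving towards stronger inhibition. Nothing measured here accounts for this step.

Since the fluorine leaves as the hydroxy group enters, the step cannot be divided between the two, and a plain phenyl group in the same place would be needed to separate them. The compounds shown also leave open whether an amine or a methoxy group in place of that hydroxy group would move the number in the same direction.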